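This account rests on a few compounds, and the source may have more. Where it says the series, first, only, none or still open, it means among the compounds named here.

Measured compounds:
compound 1, `O=C(/C=C(O)/C=C/c1cccc(O)c1)c1ccccc1O`, 40.4%
compound 2, `O=C(/C=C(O)/C=C/c1ccc(O)c(O)c1)c1ccccc1O`, 93.6%
compound 3, `COc1cc(/C=C2\CCC/C(=C\c3ccccc3)C2=O)cc(OC)c1OC`, 16.3%

In an assay on isolated protein for inhibition of Alpha glucosidase (Homo sapiens), with stated times of 5 min and 15 min, tested at 50 uM (a higher number here means more inhibition at the concentration tested (going by the name of the read-out), a lower number less inhibition), compound 2 stands highest of the three, with compound 1 nearest and compound 3 furthest, both separated from it beyond the scatter. Among the compounds with values here, the one measured step, a number 53.2 percentage points higher from compound 1 to compound 2 (beyond the scatter), concerns a hydroxy entering on the ring bearing the styryl side. Within the data shown here, compound 4, `O=C(/C=C(O)/C=C/c1ccc(O)c(O)c1)c1cc(Cl)ccc1O`, differs from compound 2 by chloro in place of hydrogen on an aromatic carbon; this sits on the other ring, so no measured step speaks to it directly. With nothing to indicate a change, and with the number of compound 2 already high in this assay, a step of about a number 6.6 percentage points lower from compound 2 to compound 4 (within the scatter) is expected, that is, none beyond the scatter. Compound 4 is therefore estimated at 87%, between 65% and 99%.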

Compound 4, a percentage reported as inhibition, at one concentration (the size of the read-out at that concentration, not a potency): 85.6%
The estimate for compound 4 lay 1.4 percentage points above the measured number; the range from low to high includes it.
By their numbers in this assay, from the lowest: compound 3; then compound 1; then compounds 4 and 2 (each within the scatter of the next).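

In this assay chloro in place of hydrogen on an aromatic carbon, para to a hydroxy group, gives a number 8 percentage points lower from compound 2 to compound 4 (within the scatter) so this position accepts a chlorine atom with no change beyond the scatter. Within the data shown here, this is the first reading at this position, since the earlier step lay elsewhere on the shared core. No measured finding accounts for this result. Open, as far as these compounds go, is whether an amine, a carboxylic acid or a methoxy group at this position would also keep the number. With both numbers high at a single concentration, any difference in potency between compound 2 and compound 4 also remains unresolved.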